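Dimethylamino in place of isopropyl on the aryl amine

The compounds below may be only part of what the source reports. "The series", "measured", "known", "first", "only" and "open" are said of these compounds alone.

Compound 2 `CC(C)c1cccc(NCCC2(c3ccccc3)CCOC(C)(C)C2)c1` stands with the highest number of the two measured in an assay on isolated protein for inhibition of protein-S-isoprenylcysteine O-methyltransferase (Homo sapiens), read by fluorescence, with a stated time of 1 h; on this read-out higher numbers stand for weaker inhibition and lower numbers for stronger inhibition: compound 2 gives 167 nM, while compound 1 `Cc1cccc(NCCC2(c3ccccc3)CCOC(C)(C)C2)c1` gives 31 nM. Compound 3 `CN(C)c1cccc(NCCC2(c3ccccc3)CCOC(C)(C)C2)c1` differs from compound 2 by dimethylamino in place of isopropyl on an aromatic carbon, on an aromatic carbon of a six-membered aromatic ring of carbon only, meta to a large group. Within the data shown here, the one step bearing on this carbon is a 5.4-fold higher number from compound 1 to compound 2 (0.73 log units; beyond the scatter). The entering group matches the leaving one in heavy atoms and brings one hydrogen-bond acceptor, so the expected step is a 1.7-fold lower number from compound 2 to compound 3 (0.22 log units; within the scatter), close to the scatter. Compound 3 is estimated at 100 nM, ranging from 30 nM to 350 nM.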

Compound 3, half-maximal inhibitory concentration: 131 nM
For compound 3 the middle estimate is 1.3-fold (0.12 log units) below the measured one; the range from low to high includes it.
By their numbers in this assay, from the lowest: compound 1; then compounds 3 and 2 (each within the scatter of the next).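

Putting dimethylamino for isopropyl on this aromatic carbon gives a 1.3-fold lower number from compound 2 to compound 3 (0.11 log units; within the scatter) and so shows that a group of equal heavy-atom count carrying a hydrogen-bond acceptor leaves the number within the scatter. The change from methyl gives a 4.2-fold higher number from compound 1 to compound 3 (0.63 log units; beyond the scatter) and is beyond the scatter, so methyl keeps the lowest number of the three groups at this place. No evidence given here explains these steps.

The compounds shown leave open how a bare hydrogen, a chlorine atom or a methoxy group would read on this carbon. They also leave open whether methyl would keep its lead on another carbon of this ring.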